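The source may hold more compounds than are shown below. What is called first, only, known or untested is meant among the compounds shown, and "the series" means these compounds.

Compound 1 `COc1ccc(-c2cc(=O)c3c(OC)cc(OC)cc3[nH]2)cc1`: in a functional assay on SEM cells (Homo sapiens) for antiproliferative activity, with a stated time of 72 h (a lower number here means that less compound is needed, a higher number that more compound is needed for the effect), compound 1 gives > 31100 nM, which is a limit of the assay and not a number.
Compound 2 `COc1ccc(-c2cc(=O)c3c(OC)cc(OC)cc3n2Cc2ccccc2)cc1`: in this assay compound 2 gives > 17300 nM, again a limit and not a number.

Compound 2 therefore stands only at a limit; compound 1 sits at the limit of > 31100 nM in this assay, at which 1 of the 2 values shown sits, and compound 2 sits at the limit of > 17300 nM in this assay, at which 1 of the 2 values shown sits. Going by the values given here, the one measured step, a step that the two limits leave unreadable from compound 1 to compound 2, runs between two limits and its size cannot be read, so it gives no guide to how much a change on the aromatic nitrogen moves potency.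

Compound 3 `C=CCNC(=O)n1c(-c2ccc(OC)cc2)cc(=O)c2c(OC)cc(OC)cc21` differs from compound 2 by allylcarbamoyl in place of benzyl on an aromatic nitrogen. Among the compounds with values here, because the only step available is a step that the two limits leave unreadable from compound 1 to compound 2, which is unreadable, no direction beyond the scatter can be expected, and compound 3 is estimated to remain weak, most likely again only as a limit. Compound 3 is expected to give about 30000 nM, between 5000 nM and 120000 nM. The estimated step that the limit leaves unreadable from compound 2 to compound 3 is thus expected to be small or not readable.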

Compound 3, half-maximal effective concentration: 12000 nM
Compound 3: middle estimate off by 2.5-fold (0.40 log units), on the high side, and the stated range covers the measured number.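

Putting allylcarbamoyl in place of hydrogen on the aromatic nitrogen gives an at least 2.5-fold lower number from compound 1 to compound 3 (0.41 log units; beyond the scatter) in this assay, so a change at this nitrogen can bring the core to a readable number. In place of benzyl, the same group gives an at least 1.4-fold lower number from compound 2 to compound 3 (0.15 log units; that floor lies within the scatter), and that floor does not separate the two groups. The size of this step stays a floor because compound 2 stands at a limit and not a number: the limit of > 17300 nM in this assay, at which 1 of the 3 values shown sits.

Going by these compounds, the step from compound 1 to compound 2 cannot be read, so what benzyl itself does on this nitrogen stays unknown. Also open, on these data alone, is which part of allylcarbamoyl matters, the carbonyl, the amide hydrogen or the allyl end, and whether a plain acetyl group, a longer chain or an amine on this nitrogen would move the number further.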